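The compounds below may be only part of what the source reports. "The series", "measured", "known", "first", "only" and "open" are said of these compounds alone.

Working notes on the series, read in a functional assay on HepG2 cells (Homo sapiens) for inhibition, read by MTT assay, with a stated time of 48 h; on this read-out lower numbers stand for stronger inhibition and higher numbers for weaker inhibition: compound 1 `CCOC(=O)C1=C(N/C=N/c2cccnc2Cl)Nc2[nH]nc(C)c2C1c1ccc(N(C)C)cc1` gives 4890 nM and compound 2 `CCOC(=O)C1=C(NN=C(C(C)=O)C(C)=O)Nc2[nH]nc(C)c2C1c1ccc(N(C)C)cc1` gives 8480 nM. Compound 2 has only compound 1 for comparison, and the two numbers lie within the scatter of each other. Still unmeasured is compound 3 `CCOC(=O)C1=C(N/N=C(/C#N)C(=O)OCC)Nc2[nH]nc(C)c2C1c1ccc(N(C)C)cc1`, where the change is a group of 9 heavy atoms (5 carbon, 2 nitrogen, 2 oxygen; no ring) in place of a group of 8 heavy atoms (5 carbon, 1 nitrogen, 2 oxygen; no ring), on an amine nitrogen. Among the compounds with values here, the one measured step on this amine nitrogen, a 1.7-fold higher number from compound 1 to compound 2 (0.24 log units; within the scatter), replaced a group with one six-membered aromatic ring by a group with no ring. No step beyond the scatter is therefore expected in this assay. The expected step is a 1.2-fold lower number from compound 2 to compound 3 (0.08 log units; within the scatter). For compound 3 the estimated value is 7000 nM, with an expected range of 2800 nM to 18000 nM.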

Compound 3, half-maximal inhibitory concentration: 46400 nM
For compound 3 the middle estimate is 6.6-fold (0.82 log units) below the measured one; the whole stated range lies below it.
By their numbers in this assay, from the lowest: compounds 1 and 2 (each within the scatter of the next); then compound 3.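

In this assay this amine nitrogen proves sensitive to its substituent: a 5.5-fold higher number from compound 2 to compound 3 (0.74 log units; beyond the scatter) shows that two groups without a ring need not read alike here. Set against the group with the six-membered aromatic ring, the entering group gives a 9.5-fold higher number from compound 1 to compound 3 (0.98 log units; beyond the scatter) as well, so the position now tolerates some groups clearly better than others. Nothing measured accounts for this difference.

The compounds shown leave open which part of the entering group carries the step. They also leave open whether a carboxylic acid or a primary amide on this nitrogen would read like compound 2 or like compound 3.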